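This account rests on a few compounds, and the source may have more. Where it says the series, first, only, none or still open, it means among the compounds named here.

Compound 1, `CC(C)c1sc(-c2ccccc2)c(-c2ccc(F)cc2)c1/C=C/[C@@H](O)C[C@@H](O)CC(=O)O`: 4.4 nM
Compound 2, `CC(C)c1sc(-c2ccc(Cl)cc2)c(-c2ccc(F)cc2)c1/C=C/[C@@H](O)C[C@@H](O)CC(=O)O`: 21 nM

In an assay on microsomes for inhibition of 3-hydroxy-3-methylglutaryl-coenzyme A reductase (Rattus norvegicus) (a lower number here means a stronger inhibitor, a higher number a weaker inhibitor), compound 1 gives 4.4 nM, while compound 2 gives 21 nM. Within the data shown here, compound 2 therefore holds the higher of the two numbers so far, and its only neighbour is compound 1, separated from it by a 4.8-fold higher number from compound 1 to compound 2 (0.68 log units; beyond the scatter). Compound 3, `Cc1ccc(-c2sc(C(C)C)c(/C=C/[C@@H](O)C[C@@H](O)CC(=O)O)c2-c2ccc(F)cc2)cc1`, has not yet been measured. It differs from compound 2 in a single place: methyl in place of chloro on an aromatic carbon. Among the measured compounds shown here, the one measured step that touches this position is a 4.8-fold higher number from compound 1 to compound 2 (0.68 log units; beyond the scatter), which showed that adding a group where compound 1 carries hydrogen raised the number. The new change keeps a group at that spot rather than returning to hydrogen, so no large movement in either direction is expected. Compound 3 is expected to stay near the level of its neighbour, with an estimated step of a 1.4-fold lower number from compound 2 to compound 3 (0.15 log units; within the scatter). Compound 3 is estimated at 15 nM, within a likely range from 5 nM to 45 nM.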

Compound 3, half-maximal inhibitory concentration: 9.7 nM
The estimate for compound 3 lay 1.5-fold (0.19 log units) above the measured number; the range from low to high includes it.
By their numbers in this assay, from the lowest: compound 1; then compound 3; then compound 2.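

In this assay, the change from 4-chlorophenyl to 4-methylphenyl gives a 2.2-fold lower number from compound 2 to compound 3 (0.34 log units; beyond the scatter), so at this position the identity of the group matters, not only whether a group is present. Methyl does not restore the level seen with hydrogen, however, as shown by a 2.2-fold higher number from compound 1 to compound 3 (0.34 log units; beyond the scatter), and so both groups tried here give a higher number than hydrogen. No measurement is available to explain why methyl and chloro differ.

Chloro and methyl are each a single heavy atom, so these compounds do not show how a larger group, such as tert-butyl or phenyl, would behave at this position. Going by these compounds, it also remains open whether fluoro, methoxy or an amine here would match the number of compound 1 or fall below it.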